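The source may hold more compounds than are shown below. What is called first, only, known or untested is meant among the compounds shown, and "the series" means these compounds.

Measured compounds:
Compound 1, `c1ccc2c(-c3cnc4[nH]nc(-c5nc6ccccc6[nH]5)c4c3)cncc2c1`, in a functional assay on A-375 cells (Homo sapiens) for antiproliferative activity (a lower number here means a stronger inhibitor, a higher number a weaker inhibitor), compound 1 gives 870 nM.
Compound 2, `COCc1cccc2[nH]c(-c3n[nH]c4ncc(-c5cccnc5)cc34)nc12`, in this assay compound 2 gives 33 nM.
Compound 3, `COCc1cccc2[nH]c(-c3n[nH]c4ncc(-c5ccncc5)cc34)nc12`, in this assay compound 3 gives 23 nM.

Compound 3 has the lowest number of the three in this assay. Its nearest neighbour is compound 2, whose number is higher by a margin that lies within the scatter of repeated measurements, so the two cannot be ranked against each other. Compound 1, which carries a different fused ring system on the shared core, stands far above both, beyond the scatter.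

The next compound, compound 4, `COCc1cccc2[nH]c(-c3n[nH]c4ncc(-c5cncnc5)cc34)nc12`, differs from compound 3 in one place: pyrimidin-5-yl in place of pyridin-4-yl on an aromatic carbon. Among the measured compounds shown here, only one measured step speaks to a change of the same kind, namely the swap of one six-membered ring with a single nitrogen for another on the same aromatic carbon, a 1.4-fold lower number from compound 2 to compound 3 (0.16 log units; within the scatter), a step within the scatter. Moving the nitrogen did little; adding a second nitrogen is a change without a direct precedent here, but nothing among the measured compounds points to a large shift in either direction. The expected step of a 1.5-fold higher number from compound 3 to compound 4 (0.18 log units; within the scatter) is therefore a small one, not beyond the scatter. Compound 4 is estimated to give 35 nM in this assay, with a likely range from 12 nM to 110 nM.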

Compound 4, half-maximal inhibitory concentration: 160 nM
Compound 4: middle estimate off by 4.6-fold (0.66 log units), on the low side; measured number outside the range, above it.
By their numbers in this assay, from the lowest: compounds 3 and 2 (each within the scatter of the next); then compound 4; then compound 1.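

In this assay, the carbon carrying this ring is not indifferent to the ring's nitrogen count: pyrimidin-5-yl in place of pyridin-4-yl gives a 7.0-fold higher number from compound 3 to compound 4 (0.84 log units; beyond the scatter), and pyrimidin-5-yl in place of pyridin-3-yl gives a 4.8-fold higher number from compound 2 to compound 4 (0.69 log units; beyond the scatter). The earlier pair could not show this, since compound 2 and compound 3 both carry a ring with 1 hetero atom and cannot be told apart; only with a ring holding 2 hetero atoms does the number move beyond the scatter, and it moves the same way from either starting compound. Nothing available here explains why the second ring nitrogen comes with a weaker result.

The compounds shown leave open whether a plain phenyl ring, with no ring nitrogen at all, or a ring bearing an amine or a carboxylic acid on this same carbon would fall with compound 3 or with compound 4. They also leave open whether pyrimidin-5-yl would bring a step of similar size on the core of compound 1, which lacks the methoxymethyl group.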